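Returning a Ring Directly to the Amide Nitrogen

The compounds below may be only part of what the source reports. "The series", "measured", "known", "first", "only" and "open" are said of these compounds alone.

In a functional assay (QGY7701 cells, Homo sapiens) for inhibition, read by MTT assay, with a stated time of 48 h (on this read-out higher numbers stand for weaker inhibition and lower numbers for stronger inhibition), compound 1 `COc1ccc2c(=O)c(/C=C/C(=O)Nc3ccc(C)cc3)coc2c1` gives 39300 nM and compound 2 `COc1ccc2c(=O)c(/C=C/C(=O)Nc3ccccc3)coc2c1` gives 14000 nM. Compound 3 `COc1ccc2c(=O)c(/C=C/C(=O)NCc3ccccc3)coc2c1` gives only a limit in this assay, > 100000 nM, so it stands at the limit of > 100000 nM in this assay, at which 1 of the 3 values shown sits, rather than at a number. The step of an at least 7.1-fold higher number from compound 2 to compound 3 (0.85 log units; beyond the scatter) and the step of an at least 2.5-fold higher number from compound 1 to compound 3 (0.40 log units; beyond the scatter) both weakened inhibition when benzyl replaced phenyl or 4-methylphenyl on the amide-type nitrogen. Compound 4 `CCOc1ccc(NC(=O)/C=C/c2coc3cc(OC)ccc3c2=O)cc1` reverses that kind of change: 4-ethoxyphenyl in place of benzyl on an amide-type nitrogen. Those two steps point the same way, and a drop in the number is therefore expected for compound 4, of a size near an at least 3.3-fold lower number from compound 3 to compound 4 (0.52 log units; beyond the scatter). Compound 4 is expected to give about 30000 nM, with a range from 8000 nM to 100000 nM.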

Compound 4, half-maximal inhibitory concentration: > 100000 nM
Compound 4: a limit, no number (the forecaster's own chance of this, stated with the estimate: 20%); at least 3.3-fold (0.52 log units) between middle value and limit.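

In this assay, an aromatic ring set directly on the amide-type nitrogen does not by itself preserve inhibition: ethoxy in place of hydrogen gives an at least 7.1-fold higher number from compound 2 to compound 4 (0.85 log units; beyond the scatter), and ethoxy in place of methyl gives an at least 2.5-fold higher number from compound 1 to compound 4 (0.40 log units; beyond the scatter). Among compounds 1, 2 and 4, the group on that ring therefore decides the outcome as well. Compound 4 gives a limit, not a number, as does compound 3, so the step between them cannot be read: the limit of > 100000 nM in this assay, at which 2 of the 4 values shown sit.

Going by these compounds, it remains open how far above the limit compound 4 lies. On these data alone, it is also open whether a hydroxyl or an amine in place of ethoxy would keep the inhibition of compound 2.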